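The source may report more compounds than this note shows. Statements on the series, on what has been measured and on what is new or still open speak of the compounds shown alone.

Measured so far in a functional assay on PC-3 cells (Homo sapiens) for inhibition, read by sulforhodamine B assay, with a stated time of 48 h, tested at 50 uM; on this read-out lower numbers stand for less inhibition of growth and higher numbers for more inhibition of growth at the one concentration tested:
- Compound 1 `COc1ccc([C@@H]2C/C(=N/OCc3cn(-c4ccc(C(=O)c5ccccc5)cc4)nn3)c3cc(CC=C(C)C)c(OC)cc3O2)cc1`: 40%
- Compound 2 `COc1ccc([C@@H]2C/C(=N/OCc3cn(-c4ccc(C#N)cc4)nn3)c3cc(CC=C(C)C)c(OC)cc3O2)cc1`: 50%
- Compound 3 `COc1cc2c(cc1CC1OC1(C)C)C(=O)C[C@@H](c1ccc(O)cc1)O2`: 92%

Compound 2, at 50%, sits with compound 1 as a pair that the usual scatter cannot separate. Both lie far under compound 3, and that gap is beyond the scatter. Within the data shown here, compound 3 is built quite differently, and no single-place step links it to compound 2, so it offers little guidance here.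

The next molecule, compound 4 `COc1ccc([C@@H]2C/C(=N/OCc3cn(-c4cccnc4Cl)nn3)c3cc(CC=C(C)C)c(OC)cc3O2)cc1`, keeps the rest of compound 2 and changes one group: 2-chloropyridin-3-yl in place of 4-cyanophenyl on an aromatic nitrogen. In plain words, 2-chloropyridin-3-yl takes the place of 4-cyanophenyl on an aromatic nitrogen of a five-membered aromatic ring with 3 nitrogen.

Among the measured compounds shown here, only one measured step bears on this. a number 10 percentage points higher from compound 1 to compound 2 (within the scatter) came from cyano replacing benzoyl within the group that now leaves, and it stayed within the scatter. For the measured compounds named here, that is a single step, and no measured compound carries the 2-chloropyridin-3-yl group, so the evidence is thin. The estimated change is no change at the digits printed from compound 2 to compound 4 (within the scatter), so no step beyond the scatter is expected in either direction in this assay. For compound 4 the estimate is 50%, with an expected range from 33% to 67%.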

Compound 4, percent growth inhibition at one concentration: 44%
For compound 4 the middle estimate is 6 percentage points above the measured one; measured number inside the range.
By their numbers in this assay, from the lowest: compounds 1, 4 and 2 (each within the scatter of the next); then compound 3.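

Replacing 4-cyanophenyl with 2-chloropyridin-3-yl on the aromatic nitrogen gives, in this assay, a number 6 percentage points lower from compound 2 to compound 4 (within the scatter), so the two compounds cannot be told apart. The earlier step changed only the group carried on a carbon-only ring, whereas this one replaces the ring itself with a ring holding a hetero atom, adds chlorine and removes the triple bond, and even so the number stays within the scatter. Compounds 1, 2 and 4 now show three different aromatic groups on this nitrogen with no listed step among them beyond the scatter, though no measurement here speaks to what lies behind this result.

The two new features of 2-chloropyridin-3-yl remain unseparated, since the compounds shown include neither a plain pyridin-3-yl group nor a 2-chlorophenyl group. On these data alone, it also remains open whether this nitrogen would tolerate something other than an aromatic ring, such as a simple alkyl chain or a chain ending in an amine or a carboxylic acid.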